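Swapping a cyclic urea for an aminotriazole on the side chain

This account rests on a few compounds, and the source may have more. Where it says the series, first, only, none or still open, it means among the compounds named here.

Measured so far in an ADME assay on microsomes from liver (Rattus norvegicus) for metabolic stability; on this read-out higher numbers stand for a longer-lived compound and lower numbers for a shorter-lived compound:
- compound 1, `CCn1ncc2c(F)cc(-c3ccc(C(CC)(CC)c4ncn(C)n4)c(=O)[nH]3)cc21`, gives > 3 h, a limit of the assay rather than a number
- compound 2, `CC(C)C(c1ccc(-c2ccc3cccc(F)c3c2)[nH]c1=O)N1CCNC1=O`, gives 0.283 h
- compound 3, `CCC(CC)(c1nnc[nH]1)c1ccc(-c2ccc3cccc(F)c3c2)[nH]c1=O`, gives 0.925 h

Of the two compounds with a proper number, compound 2 has the lower one; compound 3 stands higher, a gap beyond the usual scatter. The reading of compound 1 is only a limit, as the limit of > 3 h in this assay, at which 1 of the 3 values shown sits, shows.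

Compound 4, `CC(C)C(Nc1nnc[nH]1)c1ccc(-c2ccc3cccc(F)c3c2)[nH]c1=O`, is not yet measured. It differs from compound 2 in one place: (4H-1,2,4-triazol-3-yl)amino in place of 2-oxoimidazolidin-1-yl on a saturated chain carbon bound to an aromatic carbon and a saturated chain carbon. Compound 3 also carries a triazole ring on the same kind of chain carbon and sits higher than compound 2, so a moderate rise in this assay, in the direction of compound 3, seems plausible for compound 4, though a step within the scatter cannot be ruled out.

Compound 4 is therefore expected to give about 0.55 h, within a range of 0.2 h to 1.4 h, which means an estimated step of a 1.9-fold higher number from compound 2 to compound 4 (0.29 log units; within the scatter).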

Compound 4, half-life: 1.29 h
Compound 4: middle estimate off by 2.3-fold (0.37 log units), on the low side; low and high end bracket the measured number.
By their numbers in this assay, from the lowest: compound 2; then compounds 3 and 4 (each within the scatter of the next). At a limit, above all of these: compound 1.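

In this assay, among these compounds, this is the first comparison of two compounds that differ in one place, and it shows that the group on this saturated chain carbon matters: (4H-1,2,4-triazol-3-yl)amino in place of 2-oxoimidazolidin-1-yl gives a 4.6-fold higher number from compound 2 to compound 4 (0.66 log units; beyond the scatter). Among the compounds shown here, both groups have the same count of heavy atoms, so this change came without any growth of the side chain, although a single pair of compounds describes only this swap on this core and sets no general rule. Nothing shown here explains why the half-life changes.

From the compounds shown here alone, it remains open whether the triazole ring or the amino link carries the step, and whether a plain amine, a carboxylic acid or a longer chain at this place would behave in the same way. Going by these compounds, it is also open whether the same swap would give a similar step on a different core, such as that of compound 1.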